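A few compounds are considered here, and "the series" means these few. Any claim that something is new, unique, unknown or untested is made for them only; others in the source may bear on it.

Compound 2, whose structure is `NC(=O)c1cn(-c2ccc(O)cc2Cl)c2cc(-c3ccncc3Cl)ccc2c1=O`, is the starting point for the change described here. In an assay on isolated protein for inhibition of Calpain-1 catalytic subunit (Homo sapiens) (a lower number here means a stronger inhibitor, a higher number a weaker inhibitor), compound 2 gives 2000 nM. Its closest measured relative is compound 1, with the structure `NC(=O)c1cn(-c2ccc(O)cc2Cl)c2cc(-c3ccoc3)ccc2c1=O`, which in this assay gives 2000 nM. The two compounds share the same core and differ only in the group attached to one aromatic carbon of that core; the step of no change at the digits printed from compound 1 to compound 2 (within the scatter) shows that swapping one such group for another left the inhibition where it was. Compound 2 therefore stands level with compound 1, with nothing to separate them beyond the usual scatter.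

The next compound, compound 3, has the structure `NC(=O)c1cn(-c2ccc(O)cc2Cl)c2cc(-c3ccccn3)ccc2c1=O` and differs from compound 2 in the same place: pyridin-2-yl in place of 3-chloropyridin-4-yl on an aromatic carbon. Among the measured compounds shown here, the single earlier step at this position, no change at the digits printed from compound 1 to compound 2 (within the scatter), produced no movement, so the exchange of one small aromatic group for another here is expected to give a step of about no change at the digits printed from compound 2 to compound 3 (within the scatter), that is, none beyond the scatter. For compound 3 the estimated value in this assay is 2000 nM, with a likely range from 800 nM to 5000 nM.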

Compound 3, half-maximal inhibitory concentration: 30000 nM
Compound 3: middle estimate off by 15-fold (1.18 log units), on the low side; measured number above the stated range.
By their numbers in this assay, from the lowest: compounds 1 and 2 (each within the scatter of the next); then compound 3.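

In this assay, this position is not indifferent to the group it carries, as the level values of the first two compounds might have suggested. Putting pyridin-2-yl in place of 3-chloropyridin-4-yl gives a 15-fold higher number from compound 2 to compound 3 (1.18 log units; beyond the scatter), and putting it in place of furan-3-yl gives a 15-fold higher number from compound 1 to compound 3 (1.18 log units; beyond the scatter), even though the two pyridine groups each have one six-membered aromatic ring with 1 hetero atom and the same hydrogen-bond counts, so those shared features alone do not keep the inhibition in place. No measurement is available that would explain this large step.

The compounds shown leave open whether the higher number goes with the loss of the chlorine or with the change from a pyridin-4-yl to a pyridin-2-yl group, as the one step carries both differences. Going by these compounds, a plain pyridin-4-yl or a 3-chloropyridin-2-yl group would separate these two differences, and how a phenyl group or an amine would stand at this position also remains unknown.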